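A few compounds are considered here, and "the series" means these few. Any claim that something is new, unique, unknown or untested is made for them only; others in the source may bear on it.

Measured in an in vitro ADME assay on microsomes from liver (Homo sapiens) for metabolic stability, with a stated time of 15 min; a lower number here means slower removal, a higher number faster removal of the compound:
- compound 1 `CCc1nn2c(-c3cc(OC)c(OC)cc3OC)cccc2c1N(CC1CCOCC1)CC1CC1`: 600 mL.min-1.g-1
- compound 2 `CCc1nn2c(-c3c(COC)cc(OC)cc3OC)cccc2c1N(CC1CCOCC1)CC1CC1`: 530 mL.min-1.g-1
- compound 3 `COCc1cc(OC)c(-c2cccc3c(N(CC4CCOCC4)CC4CC4)c(C)nn23)c(OC)c1`: 110 mL.min-1.g-1

Compound 3, at 110 mL.min-1.g-1, has the lowest number of the three in this assay, and its gaps to compound 1 and compound 2 are both beyond the usual scatter. Compound 1 and compound 2 lie within the scatter of each other. No two of these compounds differ in one place only, so the values do not isolate the contribution of any single group.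

The next compound is compound 4 `COCc1cc(OC)c(-c2cccc3c(N(CC4CCOCC4)CC4CC4)c(C#N)nn23)c(OC)c1`, reached from compound 3 by placing cyano in place of methyl on an aromatic carbon. The change sits on an aromatic carbon of a five-membered aromatic ring with 2 nitrogen, part of a fused or bridged system of two rings.

Going by the values given here, no measured compound carries cyano, so the data offer no direct precedent, and the estimate is anchored on compound 3 at 110 mL.min-1.g-1. The expected change is a 1.6-fold lower number from compound 3 to compound 4 (0.20 log units; within the scatter), a modest lean toward slower removal that is not expected to lie clearly beyond the scatter. For compound 4 the estimated value is 70 mL.min-1.g-1, with an expected range from 30 mL.min-1.g-1 to 160 mL.min-1.g-1.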

Compound 4, intrinsic clearance in microsomes: 1100 mL.min-1.g-1
Estimate against measurement, compound 4: 16-fold (1.20 log units) below, and the stated range ends below it.
By their numbers in this assay, from the lowest: compound 3; then compounds 2, 1 and 4 (each within the scatter of the next, the first and the last beyond it).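

In this assay, going by these compounds alone, cyano in place of methyl on this aromatic carbon gives a 10-fold higher number from compound 3 to compound 4 (1.00 log units; beyond the scatter), the first change that can be read at a single place. Within the data shown here, this position on the five-membered aromatic ring therefore has a clear bearing on the read-out, which the earlier compounds could not show, as none of them differed in one place only. The low number of compound 3 thus depends on the group at this carbon and is not retained by the rest of the structure alone, even though the computed exchange is small: one more heavy atom, a triple bond and one hydrogen-bond acceptor. No measured evidence is available to explain the size or direction of this step.

The compounds shown leave open whether the rise is specific to cyano or would also appear with other replacements for methyl at this carbon, such as a chlorine atom, a primary amide or a hydroxymethyl group. They also leave open whether the same exchange would have a comparable effect with the aryl substitution of compound 1 or compound 2.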